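Notes on the step from compound 2 to compound 3

The source may hold more compounds than are shown below. What is called first, only, known or untested is meant among the compounds shown, and "the series" means these compounds.

Values so far in a functional assay on MCF7 cells (Homo sapiens) for cytotoxicity, read by MTT assay, with a stated time of 72 h (a lower number here means a stronger inhibitor, a higher number a weaker inhibitor), are as follows
- compound 1 (`COc1cccc(/C=C2\CCC/C(=C\c3cccc(Br)c3)C2=O)c1OC`) gives 11700 nM
- compound 2 (`COc1cccc(/C=C2\CCC/C(=C\c3ccc(O)c(Cl)c3)C2=O)c1OC`) gives 16400 nM

Compound 2 lies within the scatter of compound 1 in this assay and the two cannot be ranked. Compound 3 (`COc1cccc(/C=C2\CCC/C(=C\c3ccc(O)c(O)c3)C2=O)c1OC`) has not yet been measured. The change from compound 2 is hydroxy in place of chloro on an aromatic carbon and amounts to hydroxy in place of chloro on an aromatic carbon, ortho to a hydroxy group, turning 3-chloro-4-hydroxyphenyl into 3,4-dihydroxyphenyl. Among the measured compounds shown here, the one measured step that bears on this is a 1.4-fold higher number from compound 1 to compound 2 (0.15 log units; within the scatter) for 3-chloro-4-hydroxyphenyl in place of 3-bromophenyl. That step does not replace chloro alone, so the evidence is indirect, and it gives no ground to expect a step beyond the scatter in this assay or to favour a direction. The expected step is a 1.2-fold lower number from compound 2 to compound 3 (0.07 log units; within the scatter) on this estimate. For compound 3 the estimated value is 14000 nM with 5000 nM to 38000 nM as the expected range.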

Compound 3, half-maximal inhibitory concentration: 4700 nM
For compound 3 the middle estimate is 3.0-fold (0.47 log units) above the measured one; the measured number lies below the stated range.
By their numbers in this assay, from the lowest: compound 3; then compounds 1 and 2 (each within the scatter of the next).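

In this assay, the aromatic carbon ortho to a hydroxy group proves sensitive to what it carries: hydroxy in place of chloro gives a 3.5-fold lower number from compound 2 to compound 3 (0.54 log units; beyond the scatter) and so separates two compounds, whereas a 1.4-fold higher number from compound 1 to compound 2 (0.15 log units; within the scatter) left compound 1 and compound 2 unranked. The 3,4-dihydroxyphenyl group also stands apart from 3-bromophenyl, with a 2.5-fold lower number from compound 1 to compound 3 (0.40 log units; beyond the scatter) in the same assay, which gives compound 3 the lowest number of the three, though both steps are modest. No measurement in hand accounts for this gain.

Among the compounds shown here, whether the hydroxy group at this place needs the hydroxy group it sits ortho to remains open, because all three compounds differ in the substitution of this one aromatic ring and no pair isolates that dependence. Also open, on these data alone, are how an amine or a carboxylic acid at the same place would read in this assay and whether the same change would hold with other groups on the second aromatic ring, which is the same in all three compounds.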